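The compounds below may be only part of what the source reports. "The series", "measured", "known", "first", "only" and "open" are said of these compounds alone.

Compound 1 `O=C(CN(c1nc(Cl)nc2[nH]cnc12)C1CC1)NCC(=O)OCc1ccccc1` is the simpler of the two measured compounds, carrying only hydrogen on a saturated chain carbon bound to an amide-type nitrogen and a carbonyl carbon. In a functional assay on the whole organism (Tail, strain ICR) with Mus musculus as the target, in the tail flick test, with a stated time of 30 min, at a dose of 25 umol/kg by the oral route (on this read-out higher numbers stand for a stronger effect at the one dose given and lower numbers for a weaker effect), compound 1 gives 18.7%. Compound 2 `CC(C)[C@H](NC(=O)CN(c1nc(Cl)nc2[nH]cnc12)C1CC1)C(=O)OCc1ccccc1`, which carries isopropyl at that place, gives in this assay 33.4%, and the step of a number 14.7 percentage points higher from compound 1 to compound 2 (beyond the scatter). Compound 2 therefore stands highest of the two numbers measured, with compound 1 the nearest and lower.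

Compound 3 `C[C@@H](O)[C@H](NC(=O)CN(c1nc(Cl)nc2[nH]cnc12)C1CC1)C(=O)OCc1ccccc1` is the next compound to be measured; it differs from compound 2 by 1-hydroxyethyl in place of isopropyl on a saturated chain carbon bound to an amide-type nitrogen and a carbonyl carbon. Among the measured compounds shown here, the only measured step that bears on this place is the one from compound 1 to compound 2, which shows that a three-carbon branch rather than hydrogen went with a modest gain. For the measured compounds named here, compound 3 keeps a branch of the same size but trades two carbons for a hydroxyl-bearing carbon, a change no measured step covers, so the expected step of a number 5.4 percentage points lower from compound 2 to compound 3 (within the scatter) is small and uncertain. Compound 3 is estimated in this assay at 28%, with a range from 12% to 45%.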

Compound 3, a percentage reported as activity, at one dose (the size of the read-out at that dose, not a potency): 21.9%
Compound 3: the middle estimate sits 6.1 percentage points above what was measured, within the range that was stated.
By their numbers in this assay, from the lowest: compounds 1 and 3 (each within the scatter of the next); then compound 2.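

In this assay, 1-hydroxyethyl in place of isopropyl on the saturated chain carbon gives a number 11.5 percentage points lower from compound 2 to compound 3 (beyond the scatter), so a branch with the same number of heavy atoms does not hold the gain: swapping one carbon for an oxygen that brings a hydrogen-bond donor and acceptor is enough to change the number. Against plain hydrogen, the same group gives a number 3.2 percentage points higher from compound 1 to compound 3 (within the scatter), so at this place only isopropyl stands clearly apart from hydrogen. No measurement here explains the difference between these two branches.

As far as these compounds go, whether a methoxymethyl group, with its oxygen but no hydroxyl hydrogen, would follow isopropyl or 1-hydroxyethyl remains open. So does the effect of a longer chain, such as isobutyl, or an amine at this place.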